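Swapping iodo for bromo on a cytotoxicity read-out

The source may report more compounds than this note shows. Statements on the series, on what has been measured and on what is new or still open speak of the compounds shown alone.

Measured so far:
Compound 1, `O=c1oc2ccccc2c(=O)n1-c1ccc(Cl)cc1F`, gives 24400 nM in an ADME assay on RAW264.7 cells (Mus musculus) for cytotoxicity, read by MTT assay, with a stated time of 24 h; on this read-out lower numbers stand for higher toxicity in this test and higher numbers for lower toxicity in this test.
Compound 2, `O=c1oc2ccc(Cl)cc2c(=O)n1-c1ccc(I)cc1F`, gives 6900 nM in this assay.

Of these two numbers, compound 2 holds the lower one, and the gap to compound 1 lies beyond the usual scatter, so compound 2 reads as the more toxic of the pair in this assay. Compound 3, `O=c1oc2ccc(Cl)cc2c(=O)n1-c1ccc(Br)cc1F`, has not yet been measured. Its structure differs from compound 2 in one place: bromo in place of iodo on an aromatic carbon. Among the compounds with values here, the two halogens are close relatives, and no measured pair shows what this exchange does here. The expectation for this assay is therefore a small shift, if any, probably toward a slightly higher number and likely within the scatter, as the estimated step of a 1.3-fold higher number from compound 2 to compound 3 (0.12 log units; within the scatter) expresses. Compound 3 is estimated at 9000 nM, with a plausible range from 3500 nM to 23000 nM.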

Compound 3, half-maximal cytotoxic concentration: 8100 nM
Compound 3: middle estimate off by 1.1-fold (0.05 log units), on the high side; the measured number falls inside the stated range.
By their numbers in this assay, from the lowest: compounds 2 and 3 (each within the scatter of the next); then compound 1.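

Within the data shown here, this pair gives the first comparison that changes one place only: this assay shows a 1.2-fold higher number from compound 2 to compound 3 (0.07 log units; within the scatter) when bromo takes the place of iodo on this aromatic carbon, para to a large group. At this position the two halogens cannot be told apart on this read-out, so iodo itself is not needed for a number in this range, and bromo serves just as well. Nothing available explains why this exchange leaves the number so little changed.

As far as these compounds go, whether a different kind of group here, such as an amine, a carboxylic acid or a longer chain, would move the number beyond the scatter remains open. The separate share of the other differences between compound 1 and compound 2 also cannot be read, as those two compounds differ in more than one place.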